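From a Cyclohexyl Amide to a Benzyl Amide

The compounds below may be only part of what the source reports. "The series", "measured", "known", "first", "only" and "open" are said of these compounds alone.

Compound 2 `COc1cc2c(cc1OC)C(CC(=O)NC1CCCCC1)CC2` is an amide derived from the acid compound 1 `COc1cc2c(cc1OC)C(CC(=O)O)CC2`. In a functional assay on the whole organism (strain Wistar) for inhibition, with Rattus norvegicus as the target, read by paw edema, with stated times of 60 min and 2 h, at a dose of 100 mg/kg by the oral route (a lower number here means less inhibition, a higher number more inhibition at the dose given (going by the name of the read-out)), compound 1 gives 24%, while compound 2 gives 56%. For the measured compounds named here, compound 2 stands highest of the two numbers measured so far, and the step of a number 32 percentage points higher from compound 1 to compound 2 (beyond the scatter) shows that exchanging the acid for the amide raised inhibition well beyond the scatter.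

Compound 3 `COc1cc2c(cc1OC)C(CC(=O)NCc1ccccc1)CC2` has not yet been measured. It differs from compound 2 in one place: benzyl in place of cyclohexyl on an amide-type nitrogen. Going by the values given here, no measured step bears directly on this exchange; the single known step, from compound 1 to compound 2, concerns the carbonyl side of the amide and leaves the group on the nitrogen uncompared. Both compound 2 and compound 3 keep the amide that set compound 2 apart from compound 1, so the expectation for the step of a number 4 percentage points lower from compound 2 to compound 3 (within the scatter) is one that stays within the scatter, in no clear direction. Compound 3 is therefore estimated to give 52% in this assay, with a range from 35% to 68%.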

Compound 3, a percentage reported as inhibition, in the whole organism at one dose (the size of the read-out at that dose, not a potency): 24%
For compound 3 the middle estimate is 28 percentage points above the measured one; measured number outside the range, below it.
By their numbers in this assay, from the lowest: compounds 1 and 3 (each within the scatter of the next); then compound 2.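

The group on the amide nitrogen matters in this assay: putting benzyl in place of cyclohexyl gives a number 32 percentage points lower from compound 2 to compound 3 (beyond the scatter), so the higher reading of compound 2 cannot be credited to the amide alone. Set against the acid, the benzyl amide gives no change at the digits printed from compound 1 to compound 3 (within the scatter), whereas the cyclohexyl amide gave a number 32 percentage points higher from compound 1 to compound 2 (beyond the scatter), which means that replacing the hydroxy on the carbonyl carbon raises the reading with cyclohexylamino but not with benzylamino. Nothing available here explains why these two groups on the nitrogen give such different readings.

The compounds shown leave open whether a phenyl group on the amide nitrogen, or a longer chain such as phenylethyl, would read closer to compound 2 or to compound 3. From the compounds shown here alone, it also remains open whether a cyclopentyl group on that nitrogen would keep the reading of compound 2, which would help show how much of that reading depends on cyclohexyl itself.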